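A few compounds are considered here, and "the series" means these few. Any claim that something is new, unique, unknown or untested is made for them only; others in the source may bear on it.

Working notes on the series in a functional assay on T47D cells (Homo sapiens) for inhibition, read by sulforhodamine B assay, with a stated time of 48 h; on this read-out lower numbers stand for stronger inhibition of growth and higher numbers for weaker inhibition of growth. Compound 1 (`O=C(Cc1csc2nc(-c3ccc(Br)cc3)cn12)N/N=C/c1ccccc1`) reads > 100000 nM, which is a limit of the assay. Compound 3 (`COc1cccc(OC)c1/C=N/NC(=O)Cc1csc2nc(-c3ccc(Br)cc3)cn12`) reads > 100000 nM, also only a limit, and so it stands at the limit of > 100000 nM in this assay, at which 2 of the 3 values shown sit. Within the data shown here, compound 2 (`O=C(Cc1csc2nc(-c3ccc(Br)cc3)cn12)N/N=C/c1ccccc1O`) gives 23400 nM, the only actual number so far.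

Compound 4 (`O=C(Cc1csc2nc(-c3ccc(Br)cc3)cn12)N/N=C/c1ccc(Cl)cc1Cl`) has 2,4-dichlorophenyl in place of 2,6-dimethoxyphenyl on a carbon with a double bond to nitrogen.

The readable steps both involve the hydroxy of compound 2: an at least 4.2-fold lower number from compound 1 to compound 2 (0.63 log units; beyond the scatter) and an at least 4.2-fold higher number from compound 2 to compound 3 (0.63 log units; beyond the scatter). The third is a step that the two limits leave unreadable from compound 1 to compound 3. Compound 4 carries no hydroxy, so little gain is expected.

The expected step is modest at most, toward a lower number: an at least 1.4-fold lower number from compound 3 to compound 4 (0.15 log units; that floor lies within the scatter). The estimate for compound 4 is 70000 nM, with an expected range of 25000 nM to 100000 nM.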

Compound 4, concentration for total growth inhibition: > 100000 nM
Compound 4: only a limit was reported (the forecaster's own chance of this, stated with the estimate: 60%); middle value at least 1.4-fold (0.15 log units) from the limit.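

In this assay compound 4 reads > 100000 nM as a limit. Replacing 2-hydroxyphenyl with 2,4-dichlorophenyl gives an at least 4.2-fold higher number from compound 2 to compound 4 (0.63 log units; beyond the scatter) and so shows that a chlorine-bearing ring, like the 2,6-dimethoxyphenyl ring, does not match the hydroxy-bearing one. The steps linking compound 4 to compound 1 and compound 3 cannot be read, and the series gathers at one ceiling: the limit of > 100000 nM in this assay, at which 3 of the 4 values shown sit.

Going by these compounds, whether a hydroxy elsewhere on the ring would serve as well remains open, as does the effect of an amine or a carboxylic acid there.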